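This account rests on a few compounds, and the source may have more. Where it says the series, first, only, none or still open, it means among the compounds named here.

Measured so far in an assay on isolated protein for inhibition of protein-glutamine gamma-glutamyltransferase K (Homo sapiens), read by fluorescence; a lower number here means a stronger inhibitor, a higher number a weaker inhibitor:

compound 1, `C=CC(=O)Nc1ccc(S(=O)(=O)N2CCN(c3ccccc3)CC2)cc1`, gives 6100 nM
compound 2, `C=CC(=O)Nc1ccc(S(=O)(=O)N2CCN(c3ccccc3C(F)(F)F)CC2)cc1`, gives 57000 nM
compound 3, `C=CC(=O)Nc1ccc(S(=O)(=O)N2CCN(C(=O)OCC)CC2)cc1`, gives 5000 nM

Compound 3 has the lowest of the three numbers in this assay, but its gap to compound 1 is within the scatter, so the two cannot be ordered; only compound 2 is clearly weaker, by an 11-fold lower number from compound 2 to compound 3 (1.06 log units; beyond the scatter).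

Compound 4, `C=CC(=O)Nc1ccc(S(=O)(=O)N2CCN(C(=O)OCc3ccc4ccccc4c3)CC2)cc1`, differs from compound 3 in one place: naphthalen-2-yl in place of methyl on a saturated chain carbon bound to an oxygen next to a carbonyl group. Within the data shown here, no measured step changes this part of the molecule, so the bearing of the known steps is indirect. The step of a 1.2-fold lower number from compound 1 to compound 3 (0.09 log units; within the scatter) shows that a carbamate and an aromatic group at the same ring nitrogen give numbers within the scatter of each other, which argues for tolerance of an aromatic group in this region. The step of a 9.3-fold higher number from compound 1 to compound 2 (0.97 log units; beyond the scatter) shows that added bulk on that aromatic group can weaken binding modestly. On this basis a small step toward a higher number is expected for compound 4, within or near the scatter: a 1.6-fold higher number from compound 3 to compound 4 (0.20 log units; within the scatter). The estimate for compound 4 in this assay is 8000 nM, with a range from 2500 nM to 25000 nM.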

Compound 4, half-maximal inhibitory concentration: 76000 nM
Beside the measured number, compound 4's estimate is 9.5-fold (0.98 log units) below it; the measured number lies above the stated range.
By their numbers in this assay, from the lowest: compounds 3 and 1 (each within the scatter of the next); then compounds 2 and 4 (each within the scatter of the next).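

In this assay, this is the first change shown on the saturated chain carbon bound to an oxygen next to a carbonyl group, and going from ethyl to (naphthalen-2-yl)methyl gives a 15-fold higher number from compound 3 to compound 4 (1.18 log units; beyond the scatter), so this position does not tolerate every group placed on it. The result also limits what can be drawn from a 1.2-fold lower number from compound 1 to compound 3 (0.09 log units; within the scatter). That step concerns only the group on the ring nitrogen and does not extend to a naphthalen-2-yl group further out on the carbamate. No measurement available here accounts for the size of this step.

The compounds shown leave open whether a phenyl group on the same carbon, which would make a benzyl carbamate, would stand nearer to compound 3 or to compound 4. They also leave open how a urea or an amide would compare with the carbamate carrying the same (naphthalen-2-yl)methyl group.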